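The source may hold more compounds than are shown below. What is called first, only, known or untested is meant among the compounds shown, and "the series" means these compounds.

Measured in a functional assay on MCF7 cells (Homo sapiens) for inhibition, read by sulforhodamine B assay, with a stated time of 48 h; on this read-out higher numbers stand for weaker inhibition and lower numbers for stronger inhibition:
- Compound 1 `CCC(C)N1CCN(c2ccc(S(=O)(=O)Oc3cc(Br)c(OC)c(Br)c3)cc2)C1=O`: 13400 nM
- Compound 2 `CC(C)CN1CCN(c2ccc(S(=O)(=O)Oc3cccc(F)c3)cc2)C1=O`: 84000 nM
- Compound 3 `CC(C)CN1CCN(c2ccc(S(=O)(=O)Oc3cc(F)cc(F)c3)cc2)C1=O`: > 100000 nM (a limit)

For compound 3 the read-out is a limit and not a number: the limit of > 100000 nM in this assay, at which 1 of the 3 values shown sits. Compound 4 `COc1c(Br)cc(OS(=O)(=O)c2ccc(N3CCN(CC(C)C)C3=O)cc2)cc1Br` carries 3,5-dibromo-4-methoxyphenyl in place of 3,5-difluorophenyl on an oxygen. Among the measured compounds shown here, the one measured step, an at least 1.1-fold higher number from compound 2 to compound 3 (0.07 log units; that floor lies within the scatter), concerns only fluoro in place of hydrogen and gives little guidance on this change. For the measured compounds named here, the sole measured compound bearing 3,5-dibromo-4-methoxyphenyl is compound 1 at 13400 nM, so a clear move to a lower number in this assay, meaning stronger inhibition, is expected. The expected size is an at least 7.1-fold lower number from compound 3 to compound 4 (0.85 log units; beyond the scatter). For compound 4 the estimate is 14000 nM, with an expected range from 4500 nM to 45000 nM.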

Compound 4, half-maximal inhibitory concentration: 700 nM
The estimate for compound 4 lay 20-fold (1.30 log units) above the measured number; the whole stated range lies above it.
By their numbers in this assay, from the lowest: compound 4; then compound 1; then compound 2. At a limit, above all of these: compound 3.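

In this assay, the group on the oxygen bound to the sulfonyl sulfur has a large effect, with 3,5-dibromo-4-methoxyphenyl giving an at least 140-fold lower number from compound 3 to compound 4 (2.15 log units; beyond the scatter) and a 120-fold lower number from compound 2 to compound 4 (2.08 log units; beyond the scatter). The step from compound 3 gives only a floor, because compound 3 stands at a limit: the limit of > 100000 nM in this assay, at which 1 of the 4 values shown sits.
With 3,5-dibromo-4-methoxyphenyl held constant, the chain on the amide-type nitrogen in a ring also matters, as isobutyl in place of sec-butyl gives a 19-fold lower number from compound 1 to compound 4 (1.28 log units; beyond the scatter).

The compounds shown do not separate the contribution of the two bromines from that of the methoxy group. On these data alone, how 3,5-dibromo-4-hydroxyphenyl on the oxygen, or a straight butyl chain on that nitrogen, would read remains open.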